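Carboxymethyl on an Amino Nitrogen: A Step Not Yet Measured

The source may hold more compounds than are shown below. What is called first, only, known or untested is meant among the compounds shown, and "the series" means these compounds.

Of the compounds shown here, three have been measured in an assay on microsomes from liver for inhibition of acyl-CoA desaturase 1 (Rattus norvegicus); on this read-out lower numbers stand for stronger inhibition and higher numbers for weaker inhibition. Compound 1 `Oc1nc2cnc(N3CCC(Oc4ccccc4C(F)(F)F)CC3)nc2[nH]1` gives 38 nM, compound 2 `FC(F)(F)c1ccccc1OC1CCN(c2ncnc3[nH]cnc23)CC1` gives 10 nM, and compound 3 `Nc1nc2cnc(N3CCC(Oc4cc(F)ccc4Br)CC3)nc2s1` gives 1 nM. Compound 3 therefore stands at the lowest number of the three, and both gaps, to compound 2 and to compound 1, lie beyond the scatter of this assay, so it counts as the strongest inhibitor among them.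

Compound 4 `O=C(O)CNc1nc2cnc(N3CCC(Oc4cc(F)ccc4Br)CC3)nc2s1` has not been measured in this assay. It differs from compound 3 in one place: carboxymethyl in place of hydrogen on a nitrogen on an aromatic ring. For the measured compounds named here, no pair of measured compounds shows this kind of change, so there is no measured step to lean on; the expectation rests only on the measured compounds and the nature of the change.

The step from compound 3 to compound 4 is expected to be a modest loss, a 5.0-fold higher number from compound 3 to compound 4 (0.70 log units; beyond the scatter), somewhat beyond the scatter but uncertain in size. Compound 4 is therefore estimated at 5 nM, within a range of 1 nM to 30 nM.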

Compound 4, half-maximal inhibitory concentration: 4 nM
The estimate for compound 4 lay 1.3-fold (0.10 log units) above the measured number; measured number inside the range.
By their numbers in this assay, from the lowest: compound 3; then compound 4; then compound 2; then compound 1.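

In this assay, carboxymethyl in place of hydrogen on a nitrogen on an aromatic ring gives a 4.0-fold higher number from compound 3 to compound 4 (0.60 log units; beyond the scatter) and so costs only a modest part of the inhibition. The earlier compounds shown here held only the bare amino group at this place, so they could not show whether this nitrogen accepts anything larger. Here a group of 4 heavy atoms is accepted, and compound 4 still gives 4 nM, although this rests on a single pair of compounds.

The compounds shown do not separate the effect of the carboxylic acid from that of the added chain, a question that a methyl ester, a primary amide, a plain ethyl group or a longer acid chain on the same nitrogen could address. Nothing measured here explains the size of this step.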